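This account rests on a few compounds, and the source may have more. Where it says the series, first, only, none or still open, it means among the compounds named here.

Compound 2 `Cc1cccc(NC(=O)NCCCCC(c2ccc(F)cc2)c2ccc(F)cc2)c1` gives > 20000 nM in a functional assay on MDA-MB-231 cells (Homo sapiens) for cytotoxicity, read by MTT assay, with a stated time of 48 h (a higher number here means a weaker inhibitor, a lower number a stronger inhibitor), and this is a limit of the assay, not a number. Its close relative, compound 1 `O=C(NCCCCC(c1ccc(F)cc1)c1ccc(F)cc1)Nc1cccc(C(F)(F)F)c1`, gives 3380 nM in this assay. Among the measured compounds shown here, the one measured step is an at least 5.9-fold higher number from compound 1 to compound 2 (0.77 log units; beyond the scatter), with methyl in place of trifluoromethyl on an aromatic carbon.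

Compound 3 `CC(=O)Nc1cc(NC(=O)NCCCCC(c2ccc(F)cc2)c2ccc(F)cc2)ccc1Cl` keeps the rest of compound 2 but changes its aromatic group: 3-acetamido-4-chlorophenyl in place of 3-methylphenyl on an amide-type nitrogen. In words, 3-acetamido-4-chlorophenyl stands in place of 3-methylphenyl on an amide-type nitrogen. The measured step involves neither the acetamido nor the chloro group, so it is only a loose guide. It does show, through an at least 5.9-fold higher number from compound 1 to compound 2 (0.77 log units; beyond the scatter), that a change in this part of the series can move the result in this assay by more than the scatter. A modest move towards a lower number is therefore expected, though compound 3 may also remain without a measurable number. The expected step is an at least 2.0-fold lower number from compound 2 to compound 3 (0.30 log units; that floor lies within the scatter). For compound 3 the estimated value is 10000 nM, within an expected range from 3500 nM to 30000 nM.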

Compound 3, half-maximal inhibitory concentration: 9120 nM
For compound 3 the middle estimate is 1.1-fold (0.04 log units) above the measured one; the range from low to high includes it.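

In this assay, the aromatic group on the amide-type nitrogen can carry something other than trifluoromethyl and still give a measurable number: 3-acetamido-4-chlorophenyl in place of 3-methylphenyl gives an at least 2.1-fold lower number from compound 2 to compound 3 (0.34 log units; beyond the scatter). The size of this step is open on one side, since the value of compound 2 is a limit of the assay and not a number: the limit of > 20000 nM in this assay, at which 1 of the 3 values shown sits. Set against 3-(trifluoromethyl)phenyl, the same group gives a 2.7-fold higher number from compound 1 to compound 3 (0.43 log units; beyond the scatter), so among the three compounds shown, compound 1 keeps the lowest number, and compound 3 falls short of it while still improving on the 3-methylphenyl compound.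

The acetamido and chloro groups enter together, so the compounds shown leave open whether either one alone accounts for the step, and a phenyl group carrying only the chloro or only the acetamido would separate the two. Also open, on these data alone, is how a nitrile or a carboxylic acid on this aromatic ring would read in this assay, and whether these steps would hold on a shorter chain than the one in the shared core.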